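Swapping the Aromatic Group on a Shared Core

The compounds below may be only part of what the source reports. "The series", "measured", "known", "first", "only" and "open" are said of these compounds alone.

Measured in a functional assay on MCF7 cells (Homo sapiens) for antiproliferative activity, read by MTT assay, with stated times of 24 h and 72 h (a higher number here means a weaker inhibitor, a lower number a stronger inhibitor), the compounds read as follows:
- Compound 1 `COc1cc(N2C(=O)[C@@H](Oc3ccccc3)[C@H]2c2ccc(C#N)cc2)cc(OC)c1OC` gives 31600 nM
- Compound 2 `COc1cc(N2C(=O)[C@@H](Oc3ccccc3)[C@H]2c2ccc([N+](=O)[O-])cc2)cc(OC)c1OC` gives 63000 nM
- Compound 3 `COc1cc(N2C(=O)[C@@H](Oc3ccccc3)[C@H]2c2cccc(O)c2)cc(OC)c1OC` gives 54000 nM

Compound 3 cannot be separated from either of the other two, with a 1.7-fold higher number from compound 1 to compound 3 (0.23 log units; within the scatter) on one side and a 1.2-fold lower number from compound 2 to compound 3 (0.07 log units; within the scatter) on the other. The remaining step is a 2.0-fold higher number from compound 1 to compound 2 (0.30 log units; within the scatter) and it is equally small.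

Compound 4 `COc1cc(N2C(=O)[C@@H](Oc3ccccc3)[C@H]2c2cc(O)c(OC)c([N+](=O)[O-])c2)cc(OC)c1OC` has not yet been measured. The change from compound 3 is a group of 12 heavy atoms (7 carbon, 1 nitrogen, 4 oxygen; one six-membered aromatic ring of carbon only) in place of a group of 7 heavy atoms (6 carbon, 1 oxygen; one six-membered aromatic ring of carbon only), on a saturated ring carbon and it sits on a saturated ring carbon of a four-membered non-aromatic ring with 1 nitrogen, next to the ring nitrogen.

All three measured steps bear on this change, since each alters the aromatic group on that carbon, and none leaves the scatter. None of them brought in a group of this size, however, so they guide the expectation only loosely. A modest move towards a lower number in this assay is expected, though a step within the scatter would be no surprise. For compound 4 the expected step is a 2.7-fold lower number from compound 3 to compound 4 (0.43 log units; beyond the scatter) and it remains uncertain. Compound 4 is estimated at 20000 nM with an expected range from 1500 nM to 70000 nM around that figure.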

Compound 4, half-maximal inhibitory concentration: 69000 nM
Compound 4: middle estimate off by 3.5-fold (0.54 log units), on the low side; measured number inside the range.
By their numbers in this assay, from the lowest: compounds 1, 3, 2 and 4 (each within the scatter of the next, the first and the last beyond it).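

In this assay the aromatic group on this saturated ring carbon grew to the largest one shown, yet the number barely moved, with a 1.3-fold higher number from compound 3 to compound 4 (0.11 log units; within the scatter) and a 1.1-fold higher number from compound 2 to compound 4 (0.04 log units; within the scatter), so this larger group cannot be told apart from either smaller one. For the compounds shown here, the one step that clears the scatter is a 2.2-fold higher number from compound 1 to compound 4 (0.34 log units; beyond the scatter), and it does so only modestly, which leaves the 4-cyanophenyl group and the group of compound 4 as the only pair among the new steps that separates. Nothing shown accounts for these numbers.

On these data alone, compound 4 differs from compound 3 by more than one substituent on the aromatic ring, so the shares of its nitro, methoxy and hydroxy groups remain open, and a compound carrying only one of them alongside the hydroxy group would be needed to divide them. As far as these compounds go, it also remains open whether a pyridine or cyclohexyl ring on this carbon, or an amine or a carboxylic acid on the aromatic ring, would move the number beyond the scatter.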